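The compounds below may be only part of what the source reports. "The series", "measured", "known", "first", "only" and "open" are said of these compounds alone.

Compound 3 `O=C1O[C@@H](Cn2ccnn2)CN1c1ccc(-n2cc(-c3ccccn3)cn2)c(F)c1` gives 247000 nM in a physicochemical assay for solubility, read by HPLC, with a stated time of 24 h (on this read-out lower numbers stand for lower solubility and higher numbers for higher solubility), the smallest of the three numbers measured, though a 1.5-fold lower number from compound 2 to compound 3 (0.18 log units; within the scatter) falls within the scatter. Going by the values given here, compound 1 `CN1CCN(C[C@H]2CN(c3ccc(-n4cc(-c5ccccn5)cn4)c(F)c3)C(=O)O2)CC1` gives 1690000 nM and compound 2 `CC(=O)OC[C@H]1CN(c2ccc(-n3cc(-c4ccccn4)cn3)c(F)c2)C(=O)O1` gives 373000 nM, so a 6.8-fold lower number from compound 1 to compound 3 (0.84 log units; beyond the scatter) and a 4.5-fold lower number from compound 1 to compound 2 (0.66 log units; beyond the scatter) are the only steps that reach beyond the scatter, both following loss of the 4-methylpiperazin-1-yl group. Compound 4 `CCC(=O)NC[C@H]1CN(c2ccc(-n3cc(-c4ccccn4)cn3)c(F)c2)C(=O)O1` differs from compound 3 by propanoylamino in place of 1H-1,2,3-triazol-1-yl on a saturated chain carbon bound to a saturated ring carbon. Among the compounds with values here, the one measured exchange between two uncharged groups at this position, a 1.5-fold lower number from compound 2 to compound 3 (0.18 log units; within the scatter), stayed within the scatter, and compound 4 keeps the rest of the shared core unchanged. The step expected for compound 4 is a 1.2-fold higher number from compound 3 to compound 4 (0.08 log units; within the scatter), within the scatter. The estimate for compound 4 is 300000 nM, between 120000 nM and 800000 nM.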

Compound 4, solubility: 147000 nM
The estimate for compound 4 lay 2.0-fold (0.31 log units) above the measured number; the measured number falls inside the stated range.
By their numbers in this assay, from the lowest: compounds 4, 3 and 2 (each within the scatter of the next, the first and the last beyond it); then compound 1.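

In this assay, propanoylamino, which has no ring, takes the place of the ring of 1H-1,2,3-triazol-1-yl with a 1.7-fold lower number from compound 3 to compound 4 (0.23 log units; within the scatter) and adds a hydrogen-bond donor, so a ring at this position is not required to stay at this level. Going by these compounds alone, the exchange from acetoxy gives a 2.5-fold lower number from compound 2 to compound 4 (0.40 log units; beyond the scatter) and is the first between uncharged groups here to pass the scatter, while the exchange from 4-methylpiperazin-1-yl gives an 11-fold lower number from compound 1 to compound 4 (1.06 log units; beyond the scatter) and is the largest step at this position so far. Nothing measured here accounts for these steps. Going by these compounds, whether another amine, such as morpholin-4-yl, or a carboxylic acid on this saturated chain carbon would reach the number of compound 1 remains open.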